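Aromatic Ring Exchange on the Hydrazone of Compound 3

The source may report more compounds than this note shows. Statements on the series, on what has been measured and on what is new or still open speak of the compounds shown alone.

Compound 1 `C=CC(=O)Nc1cccc(Nc2nc(N/N=C/c3ccc(F)cc3)ncc2Cl)c1` in an ADME assay on HT-29 cells (Homo sapiens) for inhibition, read by MTT assay, with a stated time of 72 h; on this read-out higher numbers stand for weaker inhibition and lower numbers for stronger inhibition: 6340 nM
Compound 2 `C=CC(=O)Nc1cccc(Nc2nc(N/N=C(\C)c3cccc(OC)c3)ncc2Cl)c1` in this assay: 8990 nM
Compound 3 `CN(C)C/C=C/C(=O)Nc1cccc(Nc2nc(N/N=C/c3ccc(F)cc3)ncc2Cl)c1` in this assay: 3300 nM

Among these three, compound 3 has the lowest number in this assay; compound 1 stands nearest, compound 2 furthest, and only the gap to compound 2 lies beyond the scatter. Compound 4 `C/C(=N\Nc1ncc(Cl)c(Nc2cccc(NC(=O)/C=C/CN(C)C)c2)n1)c1ccccn1` differs from compound 3 in one place: a group of 9 heavy atoms (7 carbon, 2 nitrogen; one six-membered aromatic ring with 1 hetero atom) in place of a group of 9 heavy atoms (7 carbon, 1 nitrogen, 1 fluorine; one six-membered aromatic ring of carbon only), on a nitrogen on an aromatic ring. For the measured compounds named here, the single measured step, a 1.9-fold lower number from compound 1 to compound 3 (0.28 log units; within the scatter), changed the group on the carbonyl carbon and leaves the aromatic ring of the hydrazone untouched, so it does not speak to this change. Compound 1 and compound 2 also carry different aromatic groups there, but they differ in a second place as well; compound 1 gives 6340 nM and compound 2 gives 8990 nM. With no direct comparison available, no step beyond the scatter is expected for a 1.4-fold higher number from compound 3 to compound 4 (0.13 log units; within the scatter). Compound 4 is therefore estimated at 4500 nM, expected to fall between 1500 nM and 14000 nM.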

Compound 4, half-maximal inhibitory concentration: 120 nM
Compound 4: the middle estimate sits 38-fold (1.57 log units) above what was measured; measured number outside the range, below it.
By their numbers in this assay, from the lowest: compound 4; then compounds 3, 1 and 2 (each within the scatter of the next, the first and the last beyond it).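

In this assay, the group on the nitrogen on an aromatic ring turns out to be highly sensitive, with a 28-fold lower number from compound 3 to compound 4 (1.44 log units; beyond the scatter). The earlier step on the carbonyl carbon, a 1.9-fold lower number from compound 1 to compound 3 (0.28 log units; within the scatter), gave no sign of a change this large, so this position, not only that one, deserves attention. The group swap is not a single atom change, though: the carbon-only ring and its fluorine leave, while a ring with one hetero atom enters, along with a methyl group, and no information here explains the gain.

These compounds leave open whether the ring nitrogen, the methyl group or the two together account for the step. A plain phenyl ring with the same methyl group, or a pyrimidine ring in the same place, would help separate these contributions.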